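A few compounds are considered here, and "the series" means these few. Any claim that something is new, unique, unknown or untested is made for them only; others in the source may bear on it.

Compound 1, `Nc1cc(N)c2nc(-c3ccccc3)c(NCc3ccc(Cl)c(Cl)c3)nc2c1`, gives 30200 nM in a functional assay on TK-10 cells (Homo sapiens) for inhibition, read by sulforhodamine B assay, with a stated time of 48 h; a higher number here means a weaker inhibitor of growth, a lower number a stronger inhibitor of growth.
Compound 2, `CCOC(=O)[C@H](CCC(=O)O)NC(=O)c1ccc(Sc2nc3cc(N)cc(N)c3nc2-c2ccccc2)cc1`, gives < 100000 nM in this assay, which is a limit of the assay and not a number.
Compound 3, `Nc1cc(N)c2nc(-c3ccccc3)c(Sc3ccc(F)cc3)nc2c1`, gives < 100000 nM in this assay, again a limit rather than a number.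

Compound 3 therefore has no fixed place among the values recorded: it stands at a limit in this assay, and the same holds for (the limit of < 100000 nM in this assay, at which 2 of the 3 values shown sit). Only compound 1 has a number for total growth inhibition.

Compound 4, `COc1ccc(Sc2nc3cc(N)cc(N)c3nc2-c2ccccc2)cc1`, is not yet measured. It differs from compound 3 by methoxy in place of fluoro on an aromatic carbon. For the measured compounds named here, no step between two measured compounds is known, so nothing in these data tells how such a change shifts growth inhibition in this assay. Compound 4 is therefore expected to stay close to compound 3, with a step that the limit leaves unreadable from compound 3 to compound 4 that is estimated not to reach beyond the usual scatter. Compound 4 is estimated at 60000 nM, with a range from 15000 nM to 100000 nM, and it may well come back as a limit again.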

Compound 4, concentration for total growth inhibition: 30200 nM
For compound 4 the middle estimate is 2.0-fold (0.30 log units) above the measured one, within the range that was stated.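

For the compounds shown here, compound 3 stands only at a limit in this assay, so no step from it to compound 4 can be read: the limit of < 100000 nM in this assay, at which 2 of the 4 values shown sit.

The compounds shown leave open how far, if at all, methoxy in place of fluoro on an aromatic carbon shifts total growth inhibition in this assay.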